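This account rests on a few compounds, and the source may have more. Where it says the series, first, only, none or still open, it means among the compounds named here.

Measured so far in a functional assay on the whole organism (artery, strain albino) with Rattus norvegicus as the target, with a stated time of 720 min, at a dose of 10 mg/kg by the oral route; on this read-out higher numbers stand for more inhibition at the one dose given (going by the name of the read-out) and lower numbers for less inhibition:

compound 1, `COc1ccc(C2N=C(SCc3ccccc3Cl)NC(C)=C2C(=O)Nc2ccc(Br)cc2)cc1`, 10.8%
compound 2, `COc1ccc(C2N=C(SCc3ccc(Cl)cc3)NC(C)=C2C(=O)Nc2ccc(Br)cc2)cc1`, 23.7%

Compound 2 stands highest of the two numbers; its nearest neighbour is compound 1, and the step of a number 12.9 percentage points higher from compound 1 to compound 2 (beyond the scatter) came with 4-chlorophenyl in place of 2-chlorophenyl on a saturated chain carbon bound to a sulfur. Compound 3, `COc1ccc(C2N=C(SCc3ccc(F)cc3)NC(C)=C2C(=O)Nc2ccc(Br)cc2)cc1`, differs from compound 2 as follows: fluoro in place of chloro on an aromatic carbon. No measured step exchanges one halogen for another, so the one step shown does not bear on this change directly. Compound 3 is therefore expected to give a step of a number 4.7 percentage points lower from compound 2 to compound 3 (within the scatter), not beyond the scatter, with an estimated value of 19% in this assay, in a range from 6% to 32%.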

Compound 3, a percentage reported as inhibition, in the whole organism at one dose (the size of the read-out at that dose, not a potency): 19.1%
The estimate for compound 3 lay 0.1 percentage points below the measured number; the measured number falls inside the stated range.
By their numbers in this assay, from the lowest: compounds 1, 3 and 2 (each within the scatter of the next, the first and the last beyond it).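

In this assay, fluoro in place of chloro on an aromatic carbon gives a number 4.6 percentage points lower from compound 2 to compound 3 (within the scatter) and so stays inside the usual scatter, which means the 4-chlorobenzyl and 4-fluorobenzyl groups cannot be told apart here. The comparison with the 2-chlorophenyl compound gives a number 8.3 percentage points higher from compound 1 to compound 3 (within the scatter) and also stays inside the scatter, so compound 3 does not reproduce the clear separation seen for compound 2. No measurement at hand accounts for these numbers. As far as these compounds go, whether an amine or a carboxylic acid at this place would stay within that scatter remains open, as does the effect of a longer chain in place of the 4-fluorobenzyl group.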